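From thiophen-2-yl to 4-methylbenzyl at the assay limit

A few compounds are considered here, and "the series" means these few. Any claim that something is new, unique, unknown or untested is made for them only; others in the source may bear on it.

Compound 1 (`COc1ccc(S(=O)(=O)Oc2ccccc2/C=C(\C#N)C(=O)Nc2nnc(-c3cccs3)s2)cc1`): > 20000 nM
Compound 2 (`CC(=O)Nc1ccc(S(=O)(=O)Oc2cccc(/C=C(\C#N)C(=O)Nc3nnc(-c4cccs4)s3)c2)cc1`): > 20000 nM

In an ADME assay on HEK-293T cells (Homo sapiens) for inhibition, read by CCK-8 assay, with a stated time of 48 h (on this read-out lower numbers stand for stronger inhibition and higher numbers for weaker inhibition), compound 1 gives > 20000 nM as a limit, not a number. Compound 2 gives > 20000 nM and this is a limit as well. Neither compound yields a number (the limit of > 20000 nM in this assay, at which 2 of the 2 values shown sit).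

Compound 3 (`COc1ccc(S(=O)(=O)Oc2ccccc2/C=C(\C#N)C(=O)Nc2nnc(Cc3ccc(C)cc3)s2)cc1`) carries 4-methylbenzyl in place of thiophen-2-yl on an aromatic carbon. Going by the values given here, no measured step shows what such a change does in this assay, so no step beyond the scatter is expected in either direction, and another limit reading is likely. The estimated step stays small (a number no higher from compound 1 to compound 3 (the limit leaves the size open)). For compound 3 the estimate is 20000 nM, with an expected range (8000 nM to 45000 nM).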

Compound 3, half-maximal inhibitory concentration: > 50000 nM
Compound 3: no number, only a limit (the forecaster's own chance of this, stated with the estimate: 70%); middle value at least 2.5-fold (0.39 log units) from the limit.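

Going by these compounds alone, compound 1 and compound 3 both give limits rather than numbers in this assay, so no step between them can be read. The compounds shown leave open whether thiophen-2-yl or 4-methylbenzyl gives stronger inhibition.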